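Working notes: from compound 3 to compound 4

The compounds below may be only part of what the source reports. "The series", "measured", "known", "first", "only" and "open" are said of these compounds alone.

Compound 1 `N#Cc1c(-c2cccc(Br)c2)nc(SCc2cc([N+](=O)[O-])cc([N+](=O)[O-])c2)[nH]c1=O`: > 64000 nM
Compound 2 `O=c1[nH]c(SCc2cc([N+](=O)[O-])cc([N+](=O)[O-])c2)nc2ccccc12`: > 64000 nM
Compound 3 `O=c1[nH]c(SCc2ccccc2)nc2ccccc12`: > 64000 nM

All three entries come from an ADME assay on MRC5 cells (Homo sapiens) for cytotoxicity, read by neutral red uptake (a lower number here means that less compound is tolerated, a higher number that more compound is tolerated), and each is a limit of the assay rather than a number. Among the measured compounds shown here, the series so far sits at the limit of > 64000 nM in this assay, at which 3 of the 3 values shown sit. Compound 3 therefore has no numeric position, and its entry of > 64000 nM is a limit only. For the measured compounds named here, no compound in the set goes against this picture, but no number exists to show how far any of them lies from the limit.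

Compound 4 `O=c1[nH]c(SCc2cccs2)nc2ccccc12` carries thiophen-2-yl in place of phenyl on a saturated chain carbon bound to a sulfur. The entering group is one five-membered aromatic ring with 1 hetero atom.

Going by the values given here, no step between measured compounds is available to size this change. In this assay, no step beyond the scatter is expected in either direction, and this expectation rests on the shared (the limit of > 64000 nM in this assay, at which 3 of the 3 values shown sit). The expected step is a number no higher from compound 3 to compound 4 (the limit leaves the size open), which stays within the scatter. For compound 4 the estimated value is 64000 nM. The expected range for compound 4 runs from 30000 nM to 120000 nM. A further limit, rather than a number, is the most likely report.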

Compound 4, half-maximal cytotoxic concentration: > 64000 nM
Compound 4 ended at the assay's limit; the forecaster's own chance of this, stated with the estimate: 80%; the middle value sits exactly at the limit.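

In this assay compound 4 gives > 64000 nM, which is a limit of the assay and not a number. The entry for compound 3 is also a limit, so no step can be read between compound 3 and compound 4. The compounds shown leave open how far any of them lies from that limit, and whether phenyl and thiophen-2-yl differ at all.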